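From 4-hydroxyphenyl to 3,4,5-trihydroxyphenyl in compound 4

A few compounds are considered here, and "the series" means these few. Any claim that something is new, unique, unknown or untested is made for them only; others in the source may bear on it.

In a physicochemical assay, read by spectrophotometry, with a stated time of 6 min (on this read-out lower numbers stand for stronger inhibition and higher numbers for weaker inhibition), compound 1 (`O=C(CCc1nc2ccccc2c(=O)[nH]1)N/N=C/c1ccc(O)cc1`) gives 105000000 nM and so sits level with compound 2 (`COc1cc(/C=N/NC(=O)CCc2nc3ccccc3c(=O)[nH]2)cc(OC)c1OC`), which gives 55000000 nM within the scatter of it. Compound 3 (`COc1cc(/C=N/NC(=O)CCCc2nc3ccccc3c(=O)[nH]2)cc(O)c1O`) gives 50000000 nM as a lower number, just beyond the scatter from compound 1.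

Compound 4 (`O=C(CCc1nc2ccccc2c(=O)[nH]1)N/N=C/c1cc(O)c(O)c(O)c1`) has not yet been measured. It carries 3,4,5-trihydroxyphenyl in place of 4-hydroxyphenyl on a carbon with a double bond to nitrogen. Going by the values given here, no two measured compounds differ in one place only, so the data offer no direct precedent for this change. The nearest guide is compound 3 at 50000000 nM as it also carries hydroxy groups, although it differs from compound 1 elsewhere too. A modest step towards stronger inhibition is therefore expected in this assay and it should lie beyond the scatter. The estimated step is a 3.5-fold lower number from compound 1 to compound 4 (0.54 log units; beyond the scatter) on this reasoning. Compound 4 is expected at 30000000 nM with a range from 12000000 nM to 60000000 nM in this estimate.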

Compound 4, half-maximal inhibitory concentration: 35000000 nM
Estimate against measurement, compound 4: 1.2-fold (0.07 log units) below; low and high end bracket the measured number.
By their numbers in this assay, from the lowest: compounds 4, 3, 2 and 1 (each within the scatter of the next, the first and the last beyond it).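

Putting 3,4,5-trihydroxyphenyl in place of 4-hydroxyphenyl on a carbon with a double bond to nitrogen gives, in this assay, a 3.0-fold lower number from compound 1 to compound 4 (0.48 log units; beyond the scatter) with the rest of the structure unchanged. Going by these compounds alone, this is the first step that can be read at this place, and it shows that the inhibition read here responds to the groups on this aromatic ring, though only modestly. Nothing available bears on why the added hydroxy groups go with the lower number.

As far as these compounds go, it remains open whether both added hydroxy groups contribute to the step, or whether one alone would give the same reading. Also open, from the compounds shown here alone, is how an amine or a carboxylic acid on this ring would read in this assay, and whether the step would hold on a longer chain such as that of compound 3.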